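The source may hold more compounds than are shown below. What is called first, only, known or untested is meant among the compounds shown, and "the series" means these compounds.

Measured compounds:
Compound 1 `Cc1cc(=O)n(-c2ccc(F)cc2)nc1C(=O)Nc1ccc(Oc2ncnc3[nH]ccc23)cc1`: in a functional assay on A549 cells (Homo sapiens) for cytotoxicity, read by MTT assay, with a stated time of 72 h (a lower number here means a stronger inhibitor, a higher number a weaker inhibitor), compound 1 gives only a limit, > 60000 nM.
Compound 2 `Cc1cc(=O)n(-c2ccccc2OC(F)(F)F)nc1C(=O)Nc1ccc(Oc2ncnc3[nH]ccc23)cc1`: in this assay compound 2 gives 16200 nM.
Compound 3 `Cc1cc(=O)n(-c2ccc(F)cc2)nc1C(=O)Nc1ccc(Oc2ncnc3[nH]ccc23)c(F)c1`: in this assay compound 3 gives 42400 nM.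

Compound 3 carries the highest of the two numbers; compound 2 is the nearest, and its number is lower than that of compound 3 by a gap beyond the scatter. Compound 1 contributes no number, only a limit.

Compound 4 `Cc1cc(=O)n(-c2cccc(C(F)(F)F)c2)nc1C(=O)Nc1ccc(Oc2ncnc3[nH]ccc23)c(F)c1` differs from compound 3 by 3-(trifluoromethyl)phenyl in place of 4-fluorophenyl on an aromatic nitrogen. The step that bears on this change is an at least 3.7-fold lower number from compound 1 to compound 2 (0.56 log units; beyond the scatter), which is likewise a swap of the aryl group on that aromatic nitrogen, though with a different entering group; its floor is set by the limit of > 60000 nM in this assay, at which 1 of the 3 values shown sits. The other step, an at least 1.4-fold lower number from compound 1 to compound 3 (0.15 log units; that floor lies within the scatter), concerns the fluoro that compound 3 and compound 4 share and does not address the change at hand.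

A lowering of the number, modest in size, is therefore expected, namely a 2.4-fold lower number from compound 3 to compound 4 (0.37 log units; beyond the scatter). The estimate for compound 4 is 18000 nM, with a range from 6000 nM to 50000 nM.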

Compound 4, half-maximal inhibitory concentration: 35100 nM
Beside the measured number, compound 4's estimate is 2.0-fold (0.29 log units) below it; the measured number falls inside the stated range.
By their numbers in this assay, from the lowest: compound 2; then compounds 4 and 3 (each within the scatter of the next). At a limit, above all of these: compound 1.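

With the fluoro on the core kept, placing 3-(trifluoromethyl)phenyl in place of 4-fluorophenyl on the aromatic nitrogen in this assay gives a 1.2-fold lower number from compound 3 to compound 4 (0.08 log units; within the scatter), so this swap does not separate the two aryl groups. The earlier swap on the same nitrogen, to 2-(trifluoromethoxy)phenyl on the core without that fluoro, gives an at least 3.7-fold lower number from compound 1 to compound 2 (0.56 log units; beyond the scatter), so a new aryl group here does not always shift the number beyond the scatter. That earlier step is only a floor, as compound 1 gives a limit and not a number: the limit of > 60000 nM in this assay, at which 1 of the 4 values shown sits.

Still open, going by these compounds, is whether the difference between the two swaps follows the entering group or the fluoro on the core, as each swap stands on one core only. Also open, on these data alone, is how an amine or a carboxylic acid on the aryl ring, or a longer alkyl chain in place of that ring, would read in this assay.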